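A Smaller Amine Substituent and Expected Receptor Binding

The compounds below may be only part of what the source reports. "The series", "measured", "known", "first", "only" and "open" are said of these compounds alone.

Compound 1 `O[C@H]1Cc2ccccc2C1NC1CCN(CCCc2c[nH]c3ccc(-n4cnnc4)cc23)CC1`: 37 nM
Compound 2 `c1ccc(C2CCCCN2C2CCN(CCCc3c[nH]c4ccc(-n5cnnc5)cc34)CC2)cc1`: 1.9 nM
Compound 3 `CC(=O)Nc1ccc(CNC2CCN(CCCc3c[nH]c4ccc(-n5cnnc5)cc34)CC2)cc1`: 3 nM

Three compounds sharing the same core were tested in an assay on CHO cells for displacement of a labelled ligand from 5-hydroxytryptamine receptor 1D (Homo sapiens); a lower number here means a stronger inhibitor, a higher number a weaker inhibitor. Compound 1 gives the highest number of the three, so it is the weakest of them; compound 3 stands nearest, and compound 2 furthest, both beyond the scatter.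

The unmeasured compound 4 `CN(Cc1ccco1)C1CCN(CCCc2c[nH]c3ccc(-n4cnnc4)cc23)CC1` is derived from compound 1 by one change: ((furan-2-yl)methyl)(methyl)amino in place of (2-hydroxy-2,3-dihydro-1H-inden-1-yl)amino on a saturated ring carbon. Going by the values given here, the only measured step that bears on this is the one on the same amine nitrogen, a 12-fold lower number from compound 1 to compound 3 (1.09 log units; beyond the scatter), where a large saturated two-ring group was replaced by a flat one-ring group and the number fell markedly. The change to compound 4 likewise removes the two-ring group, the hydroxyl and both donors, and puts in a smaller aromatic ring on a methyl bridge. Among the compounds with values here, a step of similar direction is therefore expected in this assay, though its size is uncertain because only one comparable step, a 12-fold lower number from compound 1 to compound 3 (1.09 log units; beyond the scatter), exists.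

Compound 4 is expected to give about 5 nM, within 1.5 nM to 16 nM, which would mean an estimated 7.4-fold lower number from compound 1 to compound 4 (0.87 log units; beyond the scatter).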

Compound 4, half-maximal inhibitory concentration: 9.3 nM
Beside the measured number, compound 4's estimate is 1.9-fold (0.27 log units) below it; the measured number falls inside the stated range.
By their numbers in this assay, from the lowest: compounds 2 and 3 (each within the scatter of the next); then compound 4; then compound 1.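

The change swaps a group with 2 hydrogen-bond donors, a defined stereocentre and a hydroxyl for ((furan-2-yl)methyl)(methyl)amino, which has 0 hydrogen-bond donors and no stereocentre, and there is still a 4.0-fold lower number from compound 1 to compound 4 (0.60 log units; beyond the scatter). So a lower number at this saturated ring carbon does not depend on keeping the donors of compound 1, although compound 4 gives 9.3 nM and compound 3 gives 3 nM. Nothing measured here explains this difference or the step itself.

Going by these compounds alone, the single step alters the hydroxyl, the ring system and the substitution on the amine nitrogen together, so the share of each remains unknown. A plain ((furan-2-yl)methyl)amino group, without the methyl, or benzyl(methyl)amino, with a phenyl ring in place of the furan, would help separate these parts.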